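Testing a Dichlorophenyl Swap on a Stable Compound

The source may hold more compounds than are shown below. What is called first, only, known or untested is meant among the compounds shown, and "the series" means these compounds.

Compound 2 (`COc1cc(CN(CC(C)C)C(CC(=O)O)c2ccc3c(c2)CCO3)ccc1OCCN1C(=O)CCC1=O`) gives 100% in an ADME assay on liver (Mus musculus) for metabolic stability, read by LC-MS, using microsomes and NADPH; on this read-out higher numbers stand for a more stable compound and lower numbers for a less stable compound. Compound 1 (`Cc1cc(CN(CC2CC2)C(CC(=O)O)c2ccc(Cl)cc2)ccc1OCCN1C(=O)CCC1=O`) gives 83% on the same read-out. Compound 2 stands highest of the two measured compounds, and its gap to compound 1 lies beyond the scatter. Compound 3 (`COc1cc(CN(CC(C)C)C(CC(=O)O)c2ccc(Cl)cc2Cl)ccc1OCCN1C(=O)CCC1=O`) is not yet measured. It departs from compound 2 by one change (a group of 8 heavy atoms (6 carbon, 2 chlorine; one six-membered aromatic ring of carbon only) in place of a group of 9 heavy atoms (8 carbon, 1 oxygen; one five-membered non-aromatic ring with 1 hetero atom, one six-membered aromatic ring of carbon only), on a saturated chain carbon bound to an amine nitrogen and a saturated chain carbon): a 2,4-dichlorophenyl group enters on a saturated chain carbon bound to an amine nitrogen and a saturated chain carbon. Among the compounds with values here, no measured step isolates this change. Within the data shown here, compound 1 also carries chlorine, and its 83% is the only guide, so a modest fall is expected (a number 12 percentage points lower from compound 2 to compound 3 (beyond the scatter)), slightly beyond the scatter. For compound 3 the estimate is 88% with an expected range from 70% to 100% on this read-out.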

Compound 3, percent of the compound remaining: 67%
Estimate against measurement, compound 3: 21 percentage points above; the measured number lies below the stated range.
By their numbers in this assay, from the lowest: compound 3; then compound 1; then compound 2.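

Compound 2's group, with its five-membered non-aromatic ring, and 2,4-dichlorophenyl are not interchangeable on this saturated chain carbon in this assay: the exchange gives a number 33 percentage points lower from compound 2 to compound 3 (beyond the scatter). Within the data shown here, this step is the first to isolate a change in one place, and it shows that this place alone can move the read-out by a large amount. Nothing available explains the fall. The compounds shown leave open whether both chlorines are needed for the fall. A 2-chlorophenyl or 2,4-difluorophenyl group on the same carbon would test this.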